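The source may report more compounds than this note shows. Statements on the series, on what has been measured and on what is new or still open speak of the compounds shown alone.

Measured compounds:
compound 1 `Cc1ccc(SCc2ccc(/C=C/C(=O)Nc3ccccc3N)cc2)cc1`: 48.3%
compound 2 `Nc1ccccc1NC(=O)c1ccc(CSc2ccc(Br)cc2)cc1`: 45.7%

Both compounds were tested in a functional assay on A549 cells (Homo sapiens) for inhibition, read by CCK-8 assay, with a stated time of 72 h, tested at 8 uM; on this read-out higher numbers stand for more inhibition of growth at the one concentration tested and lower numbers for less inhibition of growth. Compound 1 gives the numerically higher of the two values there, yet compound 2 lies within the usual scatter of it, so no order between the two can be claimed. The compound still to be measured is compound 3 `CC(C)(C)c1ccc(SCc2ccc(/C=C/C(=O)Nc3ccccc3N)cc2)cc1`, which differs from compound 1 in one place: tert-butyl in place of methyl on an aromatic carbon. Among the measured compounds shown here, no pair of measured compounds shows what such a change does on this read-out, so the expectation rests on the change itself, tert-butyl in place of methyl on an aromatic carbon, which alters neither donors nor acceptors nor charge. The step from compound 1 to compound 3 is therefore expected to be small, with no direction beyond the scatter, at about a number 1.7 percentage points higher from compound 1 to compound 3 (within the scatter). Compound 3 is accordingly estimated at 50%, within a range from 32% to 68%.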

Compound 3, percent growth inhibition at one concentration: 79.8%
For compound 3 the middle estimate is 29.8 percentage points below the measured one; the whole stated range lies below it.
By their numbers in this assay, from the lowest: compounds 2 and 1 (each within the scatter of the next); then compound 3.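

In this assay, the change from 4-methylphenyl to 4-(tert-butyl)phenyl gives a number 31.5 percentage points higher from compound 1 to compound 3 (beyond the scatter) and is a large step, so this position on the aromatic ring responds strongly to the group it carries. That step comes with a change in the alkyl group alone, with no hydrogen-bond donors, hydrogen-bond acceptors or net charge entering or leaving. The information at hand gives no measurement that accounts for the step.

As far as these compounds go, whether ethyl or isopropyl at this position would give a value between those of compound 1 and compound 3 remains open. So does whether an amine, a carboxylic acid or a longer chain in the same place would keep the higher value seen with compound 3 79.8%.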